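Swapping a Phenyl for a Methyl on the Pyranone

The source may report more compounds than this note shows. Statements on the series, on what has been measured and on what is new or still open speak of the compounds shown alone.

Of the compounds shown here, three sharing one dihydropyridine-like core have been tested in an assay on isolated protein (strain albino) for inhibition of Voltage-dependent L-type calcium channel subunit alpha-1C (Cavia porcellus); on this read-out higher numbers stand for weaker inhibition and lower numbers for stronger inhibition. Compound 1 `COC(=O)C1=C(C)NC(C)=C(C(=O)OC)C1c1ccc(-c2cc(=O)cc(C)o2)cc1` gives 17800 nM, compound 2 `CCOC(=O)C1=C(C)NC(C)=C(C(=O)OCC)C1c1ccc(-c2cc(=O)cc(C)o2)cc1` gives 2140 nM, and compound 3 `CCOC(=O)C1=C(C)NC(C)=C(C(=O)OC)C1c1ccc(-c2cc(=O)cc(-c3ccccc3)o2)cc1` gives 94400 nM, the highest number of the three and therefore the weakest inhibitor of this set, clearly beyond the scatter from both others. Compound 4 `CCOC(=O)C1=C(C)NC(C)=C(C(=O)OC)C1c1ccc(-c2cc(=O)cc(C)o2)cc1` has not yet been measured. It differs from compound 3 by a single change: methyl in place of phenyl on an aromatic carbon. Because compound 1 gives 17800 nM and compound 2 gives 2140 nM, both carrying the methyl, a substantially lower number is expected for compound 4. The step from compound 3 to compound 4 is estimated at a 16-fold lower number from compound 3 to compound 4 (1.20 log units; beyond the scatter). In this assay compound 4 is expected to give about 6000 nM, within a range from 2000 nM to 20000 nM.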

Compound 4, half-maximal inhibitory concentration: 86100 nM
Compound 4: middle estimate off by 14-fold (1.16 log units), on the low side; measured number above the stated range.
By their numbers in this assay, from the lowest: compound 2; then compound 1; then compounds 4 and 3 (each within the scatter of the next).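

In this assay exchanging phenyl for methyl at this position makes no real difference (a 1.1-fold lower number from compound 3 to compound 4 (0.04 log units; within the scatter)), so in this pairing of ester chains the two groups cannot be told apart. The ester chains do separate the compounds, and both directions of change raise the number: adding a methyl to one chain (a 4.8-fold higher number from compound 1 to compound 4 (0.68 log units; beyond the scatter)) and removing one (a 40-fold higher number from compound 2 to compound 4 (1.60 log units; beyond the scatter)). Nothing available explains these shifts.

From the compounds shown here alone, whether phenyl and methyl also match when both ester chains are ethyl or both are methyl remains open. So does the effect of an amine or a longer chain such as butyl at this position.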